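This account rests on a few compounds, and the source may have more. Where it says the series, first, only, none or still open, it means among the compounds named here.

Compound 1 `CC1(C)C[C@H](O)C[C@](C)(CNc2cccc(S(N)(=O)=O)c2)C1` and compound 2 `CC1(C)C[C@H](O)C[C@](C)(CNc2cc(Cl)cc(S(N)(=O)=O)c2)C1` share one core, and compound 2 carries a chloro where compound 1 carries hydrogen. In an ADME assay on MDCK cells (Canis lupus familiaris) for cytotoxicity, read by MTT assay, with a stated time of 3 days (on this read-out lower numbers stand for higher toxicity in this test and higher numbers for lower toxicity in this test), compound 1 gives > 100000 nM, which is a limit of the test rather than a number; this is the limit of > 100000 nM in this assay, at which 1 of the 2 values shown sits. In this assay compound 2 gives 8400 nM, the only number shown. The step of an at least 11-fold lower number from compound 1 to compound 2 (1.07 log units; beyond the scatter) is large. Compound 3 `CC1(C)C[C@H](O)C[C@](C)(CNc2cc(C(F)(F)F)cc(S(N)(=O)=O)c2)C1` differs from compound 2 by trifluoromethyl in place of chloro on an aromatic carbon. No measured step covers this swap; the one step shown, an at least 11-fold lower number from compound 1 to compound 2 (1.07 log units; beyond the scatter), tells only that a group at this site can move the number a lot. The step expected here is a 1.4-fold lower number from compound 2 to compound 3 (0.15 log units; within the scatter). Compound 3 is estimated at 6000 nM in this assay, between 2000 nM and 20000 nM.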

Compound 3, half-maximal cytotoxic concentration: 19500 nM
For compound 3 the middle estimate is 3.3-fold (0.51 log units) below the measured one, and the stated range covers the measured number.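

Trifluoromethyl in place of chloro at this site is not a neutral swap in this assay: the result is a 2.3-fold higher number from compound 2 to compound 3 (0.37 log units; beyond the scatter), which here means lower toxicity in this test. Trifluoromethyl still leaves a clear gap to hydrogen, with an at least 5.1-fold lower number from compound 1 to compound 3 (0.70 log units; beyond the scatter). Compound 1 gives a limit of the test, not a number, so that gap has no exact size: the limit of > 100000 nM in this assay, at which 1 of the 3 values shown sits.

As far as these compounds go, what an amine, a carboxylic acid or a longer chain at this site would do to the number stays open. So does whether the order seen among hydrogen, chloro and trifluoromethyl holds on any other core.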